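Replacing the Chlorobenzyl Amide: Expectation for Compound 4

This account rests on a few compounds, and the source may have more. Where it says the series, first, only, none or still open, it means among the compounds named here.

The measured compounds, all sharing one core, and their values in an assay on microsomes from liver for inhibition of 3-hydroxy-3-methylglutaryl-coenzyme A reductase (Rattus norvegicus); a lower number here means a stronger inhibitor, a higher number a weaker inhibitor:
Compound 1, `CC(C)c1c(C(=O)NCC2CCCCC2)nn(-c2ccc(F)cc2)c1OC[C@@H](O)C[C@@H](O)CC(=O)O`: 17 nM
Compound 2, `COc1cccc(CNC(=O)c2nn(-c3ccc(F)cc3)c(OC[C@@H](O)C[C@@H](O)CC(=O)O)c2C(C)C)c1`: 16 nM
Compound 3, `CC(C)c1c(C(=O)NCc2cccc(Cl)c2)nn(-c2ccc(F)cc2)c1OC[C@@H](O)C[C@@H](O)CC(=O)O`: 5.4 nM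

Compound 3 gives the lowest number of the three, and both of its steps are beyond the scatter: a 3.1-fold lower number from compound 1 to compound 3 (0.50 log units; beyond the scatter) and a 3.0-fold lower number from compound 2 to compound 3 (0.47 log units; beyond the scatter). Compound 1 and compound 2 show values within the scatter of each other, as a 1.1-fold lower number from compound 1 to compound 2 (0.03 log units; within the scatter) tells.

Compound 4, `CC(C)c1c(C(=O)N(C)[C@H](C)c2ccccc2)nn(-c2ccc(F)cc2)c1OC[C@@H](O)C[C@@H](O)CC(=O)O`, differs from compound 3 in one place: methyl(1-phenylethyl)amino in place of (3-chlorobenzyl)amino on a carbonyl carbon.

Within the data shown here, two measured steps bear on this change. The step of a 3.0-fold lower number from compound 2 to compound 3 (0.47 log units; beyond the scatter) shows that the chloro on the aromatic ring matters modestly, and compound 4 loses it. The step of a 3.1-fold lower number from compound 1 to compound 3 (0.50 log units; beyond the scatter) shows that an aromatic ring in this position is favourable over a saturated one, and compound 4 keeps an aromatic ring. Among the measured compounds shown here, no measured step touches the nitrogen itself or the extra methyl on the saturated chain carbon, so that part of the change is uncharted.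

On balance, compound 4 is expected to give a higher number than compound 3, a step of a 3.7-fold higher number from compound 3 to compound 4 (0.57 log units; beyond the scatter). The estimate for compound 4 in this assay is 20 nM, with a range from 6 nM to 70 nM.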

Compound 4, half-maximal inhibitory concentration: 21 nM
Beside the measured number, compound 4's estimate is 1.1-fold (0.02 log units) below it; low and high end bracket the measured number.
By their numbers in this assay, from the lowest: compound 3; then compounds 2, 1 and 4 (each within the scatter of the next).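

In this assay, the swap on the carbonyl carbon gives a 3.9-fold higher number from compound 3 to compound 4 (0.59 log units; beyond the scatter), so the advantage held by the (3-chlorobenzyl)amino group does not carry over to methyl(1-phenylethyl)amino, a group with no chlorine, no amide hydrogen and one defined stereocentre. Against the other two amides, the steps are a 1.3-fold higher number from compound 2 to compound 4 (0.12 log units; within the scatter) and a 1.2-fold higher number from compound 1 to compound 4 (0.09 log units; within the scatter), which places compound 4 level with both and shows that this position can lose the amide hydrogen and still match compound 1 and compound 2, which both keep it. No measurement here gives a reason for the rise from compound 3 to compound 4.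

As far as these compounds go, the swap changes several things at once, so the share of the chlorine, the methyl on the nitrogen and the methyl on the chain carbon stays unresolved, and the effect of the stereocentre stays open as well. A plain benzyl amide, an N-methyl-3-chlorobenzyl amide and the mirror-image form of the 1-phenylethyl group would each isolate one of these parts, while a carboxylic acid or an amine on the aromatic ring would test a quite different kind of substituent.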